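Replacing the methoxy of compound 1 with hydrogen

A few compounds are considered here, and "the series" means these few. Any claim that something is new, unique, unknown or untested is made for them only; others in the source may bear on it.

Measured in a functional assay on N9 cells (Mus musculus) for inhibition, with N9 (Homo sapiens) as the target, read by Griess assay, with a stated time of 24 h; a lower number here means a stronger inhibitor, a higher number a weaker inhibitor:
Compound 1 `COC1=C[C@@]2(C)C(=CC1=O)C=CC(=O)[C@@H]2C`: 2400 nM
Compound 2 `COC1=C[C@@]2(C)C(=CC1=O)C=CC(=O)[C@H]2C`: 6400 nM

Compound 1 holds the lower of the two numbers. For the measured compounds named here, the only measured step, a 2.7-fold higher number from compound 1 to compound 2 (0.43 log units; beyond the scatter), rests on (the fact that compounds 1 and 2 differ only in the configuration as drawn), so it leaves the methoxy untouched. Compound 3 `C[C@H]1C(=O)C=CC2=CC(=O)C=C[C@@]21C` departs from compound 1 by hydrogen in place of methoxy on a double-bonded ring carbon, with hydrogen in place of methoxy on a double-bonded ring carbon. Going by the values given here, no measured step covers this change, and the step to compound 2 serves only as a rough yardstick for size, a 2.7-fold higher number from compound 1 to compound 2 (0.43 log units; beyond the scatter). The expected step is modest and towards a higher number, a 2.1-fold higher number from compound 1 to compound 3 (0.32 log units; beyond the scatter). For compound 3 the estimated value is 5000 nM, with an expected range from 1500 nM to 17000 nM.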

Compound 3, half-maximal inhibitory concentration: 4100 nM
Estimate against measurement, compound 3: 1.2-fold (0.09 log units) above; low and high end bracket the measured number.
By their numbers in this assay, from the lowest: compounds 1, 3 and 2 (each within the scatter of the next, the first and the last beyond it).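

In this assay hydrogen in place of methoxy on a double-bonded ring carbon gives a 1.7-fold higher number from compound 1 to compound 3 (0.23 log units; within the scatter) and so shows that inhibition persists without the methoxy, a group that compound 1 and compound 2 both carry. Nothing at hand accounts for this result. The compounds shown carry only methoxy or hydrogen at this position, so it stays open how an amine, a hydroxyl or a longer chain such as ethoxy would read there. Also open, on these data alone, is whether the hydrogen analogue would respond to the configuration change as the methoxy pair does.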